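This account rests on a few compounds, and the source may have more. Where it says the series, first, only, none or still open, it means among the compounds named here.

Of the compounds shown here, three with a shared core have been measured in a physicochemical assay for solubility, in phosphate buffer, with a stated time of 24 h, at pH 7.4; on this read-out lower numbers stand for lower solubility and higher numbers for higher solubility. Compound 1 `CCCS(=O)(=O)NC(=O)c1cc(COc2ccc(-c3ccc(OC)cc3)cc2)c(C)o1` gives 7 ug/mL, compound 2 `COc1ccc(-c2ccc(OCc3cc(C(=O)NS(=O)(=O)c4ccccc4)oc3C)cc2)cc1` gives 11 ug/mL, and compound 3 `COc1ccc(-c2ccc(OCc3cc(C(=O)NS(=O)(=O)c4c(C)noc4C)oc3C)cc2)c(C)c1` gives 200 ug/mL, the highest of the three and well beyond the scatter from the other two. Compound 4 `Cc1noc(C)c1S(=O)(=O)NC(=O)c1cc(COc2ccc(-c3ccc(OC(F)F)cc3)cc2)c(C)o1` keeps the group on the sulfonyl sulfur of compound 3 and differs in one place: 4-(difluoromethoxy)phenyl in place of 4-methoxy-2-methylphenyl on an aromatic carbon, para to a large group (4-(difluoromethoxy)phenyl in place of 4-methoxy-2-methylphenyl on an aromatic carbon).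

Going by the values given here, the only measured single-place step, a 1.6-fold higher number from compound 1 to compound 2 (0.20 log units; within the scatter), lies within the scatter and concerns the sulfonyl sulfur, so it says nothing direct about this change. There is one indirect clue. Compound 1, at 7 ug/mL, and compound 2, at 11 ug/mL, also lack the methyl that is lost here. Among the compounds with values here, both also differ from compound 3 on the sulfonyl sulfur, however, so the data cannot separate the two places, and no measured compound carries the difluoromethoxy group. A partial fall in this assay is therefore expected, with wide uncertainty, and the estimated step is a 3.3-fold lower number from compound 3 to compound 4 (0.52 log units; beyond the scatter). For compound 4 the expected value is 60 ug/mL, with an estimated range from 15 ug/mL to 200 ug/mL.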

Compound 4, solubility: < 0.6 ug/mL
Compound 4 gave a limit, no number (the forecaster's own chance of this, stated with the estimate: 5%); at least 100-fold (2.00 log units) between middle value and limit.
By their numbers in this assay, from the lowest: compounds 1 and 2 (each within the scatter of the next); then compound 3. At a limit, below all of these: compound 4.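

In this assay, this single change, made on an aromatic carbon para to a large group while the group on the sulfonyl sulfur stays as in compound 3, gives an at least 330-fold lower number from compound 3 to compound 4 (2.52 log units; beyond the scatter). Going by these compounds alone, the only earlier step, a 1.6-fold higher number from compound 1 to compound 2 (0.20 log units; within the scatter), lay on the sulfonyl sulfur and stayed within the scatter, so this is the first direct sign that the outer aromatic ring can move this read-out strongly, and that the sulfonyl group of compound 3 does not by itself hold the number at the level of compound 3. Compound 4 gives a limit and not a number, < 0.6 ug/mL, so the step has a bound rather than a known size, and only this one compound sits there: the limit of < 0.6 ug/mL in this assay, at which 1 of the 4 values shown sits.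

The swap removes a methyl and turns methoxy into difluoromethoxy at once, so the compounds shown cannot say which of the two alterations accounts for the step, or whether both are needed. Also open, from the compounds shown here alone, is how this assay would read with plain 4-methoxyphenyl alongside the sulfonyl group of compound 3, or with an amine or a carboxylic acid on this outer ring.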